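A few compounds are considered here, and "the series" means these few. Any claim that something is new, unique, unknown or untested is made for them only; others in the source may bear on it.

In a functional assay on RT-112 cells (Homo sapiens) for antiproliferative activity, read by MTT assay, with a stated time of 72 h (a lower number here means a stronger inhibitor of growth, a higher number a weaker inhibitor of growth), compound 1 `COc1cc(Nc2ncnc3c(NC(=O)Nc4cc(Cl)c(Cl)cc4Cl)cccc23)cc(OC)c1` gives 4890 nM. Compound 2 `COc1cc(Nc2ncnc3c(NC(=O)Nc4ccc(Cl)c(C(F)(F)F)c4)cccc23)cc(OC)c1` is reported only as a limit, > 20000 nM. Compound 3 `COc1cc(Nc2ncnc3c(NC(=O)Nc4ccc([N+](=O)[O-])cc4)cccc23)cc(OC)c1` also stands at a limit, > 20000 nM, so it has no exact value. Compound 4 `COc1cc(Nc2ncnc3c(NC(=O)Nc4cccc(C)c4C)cccc23)cc(OC)c1` carries 2,3-dimethylphenyl in place of 4-nitrophenyl on an amide-type nitrogen. Three measured steps change this same group: an at least 4.0-fold higher number from compound 1 to compound 2 (0.61 log units; beyond the scatter), an at least 4.0-fold higher number from compound 1 to compound 3 (0.61 log units; beyond the scatter) and a step that the two limits leave unreadable from compound 2 to compound 3. The first two are beyond the scatter, and the third cannot be sized. Only compound 1 gives an exact value, at 4890 nM, so only a modest gain is expected for compound 4. The expected step toward a lower number in this assay is an at least 1.6-fold lower number from compound 3 to compound 4 (0.22 log units; that floor lies within the scatter). Compound 4 is estimated at 12000 nM, with an expected range of 4000 nM to 30000 nM.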

Compound 4, concentration for 50% growth inhibition: 5910 nM
Compound 4: middle estimate off by 2.0-fold (0.31 log units), on the high side, and the stated range covers the measured number.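

Compound 4 shows that chlorine on this ring is not needed for a measurable value in this assay, since 2,3-dimethylphenyl and 2,4,5-trichlorophenyl cannot be told apart: a 1.2-fold higher number from compound 1 to compound 4 (0.08 log units; within the scatter). The same dimethyl ring also separates clearly from the two weaker groups, with an at least 3.3-fold lower number from compound 3 to compound 4 (0.52 log units; beyond the scatter) and an at least 3.3-fold lower number from compound 2 to compound 4 (0.52 log units; beyond the scatter). Compound 2 and compound 3 each stand at a limit, so those two steps are only floors: the limit of > 20000 nM in this assay, at which 2 of the 4 values shown sit.

On these data alone, it remains open whether one methyl group alone would serve as well as two. An amine or a carboxylic acid on this ring is also untested among the compounds shown.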